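This account rests on a few compounds, and the source may have more. Where it says the series, first, only, none or still open, it means among the compounds named here.

In a functional assay on SF-539 cells (Homo sapiens) for antiproliferative activity, with a stated time of 48 h (on this read-out lower numbers stand for higher toxicity in this test and higher numbers for lower toxicity in this test), compound 1 `Cc1cc(O)c(C2=NN(c3ccc(S(N)(=O)=O)cc3)C(c3ccccc3Cl)C2)cc1Cl` gives 5900 nM, and compound 2 `COc1ccc(C2CC(c3cc(Cl)c(C)cc3O)=NN2c2ccc(S(N)(=O)=O)cc2)cc1OC` gives 12000 nM. Going by the values given here, the single measured step, a 2.0-fold higher number from compound 1 to compound 2 (0.31 log units; beyond the scatter), thus raised the number by a modest amount. Among the compounds with values here, compound 2 therefore stands at the higher of the two numbers, with compound 1 as its only neighbour at a lower value. Compound 3 `COc1ccc(C2CC(c3cc(Cl)c(C)cc3O)=NN2c2ccc(S(N)(=O)=O)cc2)c(OC)c1OC` differs from compound 2 by methoxy in place of hydrogen on an aromatic carbon. Within the data shown here, no measured step touches this particular change; the only step in hand, from compound 1 to compound 2, exchanged the whole group on the saturated ring carbon rather than adding a single methoxy, so it bears on the new step only loosely. The expectation is therefore a step of no clear direction, with an estimated 1.1-fold higher number from compound 2 to compound 3 (0.03 log units; within the scatter) that stays within the scatter. Compound 3 is accordingly expected to give about 13000 nM in this assay, in a range from 6000 nM to 30000 nM.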

Compound 3, concentration lethal to 50% of the cells: 6420 nM
Beside the measured number, compound 3's estimate is 2.0-fold (0.31 log units) above it, and the stated range covers the measured number.
By their numbers in this assay, from the lowest: compounds 1, 3 and 2 (each within the scatter of the next, the first and the last beyond it).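

In this assay, methoxy in place of hydrogen on an aromatic carbon, ortho to a large group and ortho to a methoxy group, gives a 1.9-fold lower number from compound 2 to compound 3 (0.27 log units; within the scatter), so this place takes the added methoxy without a step beyond the scatter. The change from 2-chlorophenyl to 2,3,4-trimethoxyphenyl gives a 1.1-fold higher number from compound 1 to compound 3 (0.04 log units; within the scatter), whereas the change to 3,4-dimethoxyphenyl had given a 2.0-fold higher number from compound 1 to compound 2 (0.31 log units; beyond the scatter), so only the latter separates from 2-chlorophenyl beyond the scatter. No evidence is at hand that would explain these numbers.

From the compounds shown here alone, whether an amine, a hydroxyl or a longer chain such as butoxy at this same place would give a step beyond the scatter stays open. Going by these compounds, it also stays open whether methoxy at this place would read the same with a chlorine elsewhere on the ring.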